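Removing the methyl group from compound 3

This account rests on a few compounds, and the source may have more. Where it says the series, first, only, none or still open, it means among the compounds named here.

In an ADME assay on BHK-21 cells (Mesocricetus auratus) for cytotoxicity, read by MTT assay, with a stated time of 72 h (on this read-out higher numbers stand for lower toxicity in this test and lower numbers for higher toxicity in this test), compound 3 (`Cc1ccc(NCc2cn(-c3ccccc3)nc2-c2ccc(Br)cc2)cc1`) gives > 100000 nM as a limit of the assay and not a number. With trifluoromethyl in place of that methyl, compound 1 (`FC(F)(F)c1ccc(NCc2cn(-c3ccccc3)nc2-c2ccc(Br)cc2)cc1`) gives 20000 nM as a true measured number. Among the compounds with values here, that change, seen as the step of an at least 5.0-fold higher number from compound 1 to compound 3 (0.69 log units; beyond the scatter), is the only measured step at this place, and it involves a different pair of groups from the one considered here.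

Compound 4 (`Brc1ccc(-c2nn(-c3ccccc3)cc2CNc2ccccc2)cc1`) has hydrogen in place of methyl on an aromatic carbon, para to a large group (hydrogen in place of methyl on an aromatic carbon). It carries no trifluoromethyl at that place. Like it, compound 2 (`Cc1ccc(-c2nn(-c3ccccc3)cc2CNc2ccccc2)cc1`) has the anilino group and gives > 100000 nM as another limit of the assay. Any further rise would stay hidden due to the limit of > 100000 nM in this assay, at which 2 of the 3 values shown sit, in this test. No change beyond the scatter is therefore expected in this assay, and the estimated step is a number no higher from compound 3 to compound 4 (the limit leaves the size open) on this evidence. Compound 4 is expected at 100000 nM with an estimated range of 40000 nM to 200000 nM. A limit of the assay rather than a number is also expected for compound 4.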

Compound 4, half-maximal cytotoxic concentration: > 100000 nM
Compound 4 gave a limit, no number; the forecaster's own chance of this, stated with the estimate: 65%; the middle value lies on the limit itself.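

Within the data shown here, at this place on the anilino group, hydrogen now joins methyl in leaving the read-out at its limit, while trifluoromethyl is the only one of the three groups to give a true number. In this assay, the change from trifluoromethyl to hydrogen gives an at least 5.0-fold higher number from compound 1 to compound 4 (0.69 log units; beyond the scatter), so the rise seen earlier does not depend on methyl being present. The steps joining compound 4 to compound 3 and to compound 2 cannot be read, because all three compounds sit at a limit: the limit of > 100000 nM in this assay, at which 3 of the 4 values shown sit.

How far methyl and hydrogen differ here, and how far bromo and methyl differ at the other place, therefore stays hidden. As far as these compounds go, whether a chloro, methoxy or carboxylic acid group at this place would also give a true number remains open.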